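This account rests on a few compounds, and the source may have more. Where it says the series, first, only, none or still open, it means among the compounds named here.

Of the compounds shown here, three have so far been tested in a physicochemical assay for metabolic stability, read by LC-MS, in phosphate buffer, with a stated time of 3 h, at pH 7.4, tested at 50 uM; on this read-out higher numbers stand for a more stable compound and lower numbers for a less stable compound. Compound 1, `C[C@@H](O)[C@H]1C(=O)N2C3=C(S[C@@H]4CN[C@@H](C4)C(=O)Nc4cccc(c4)C(=O)OCOCOC3=O)[C@H](C)[C@H]12`, gives > 95%, which is a limit of the assay rather than a number. Compound 2, `CCOC(=O)C1=C(S[C@@H]2CN[C@H](C(=O)Nc3cccc(C(=O)OCC)c3)C2)[C@H](C)[C@@H]2[C@@H]([C@@H](C)OC(C)=O)C(=O)N12`, gives > 95%, again a limit of the assay. Compound 3, `CCOC(=O)C1=C(S[C@@H]2CN[C@H](C(=O)Nc3cccc(C(=O)OCC)c3)C2)[C@H](C)[C@@H]2[C@@H]([C@@H](C)O)C(=O)N12`, gives > 95%, also a limit of the assay. Compound 3 and compound 2 differ in one place only: acetyl in place of hydrogen on an oxygen on a saturated carbon. The step that the two limits leave unreadable from compound 3 to compound 2 cannot be sized, since (the limit of > 95% in this assay, at which 3 of the 3 values shown sit). The difference between the core of compound 1 and the core of compound 3 is not broken down here.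

Compound 4, `CC(=O)O[C@H](C)[C@H]1C(=O)N2C3=C(S[C@@H]4CN[C@@H](C4)C(=O)Nc4cccc(c4)C(=O)OCOCOC3=O)[C@H](C)[C@H]12`, has not yet been measured in this assay. It differs from compound 1 in the same way that compound 2 differs from compound 3, namely (acetyl in place of hydrogen on an oxygen on a saturated carbon), and the surroundings of the place are described in the same words, so it is the same change. All that can be read from the measured pair is that both members sit at the limit of the assay, so the change left no readable trace there. The expected step is a number no higher from compound 1 to compound 4 (the limit leaves the size open). That expectation rests on compound 2, whose value > 95% is a limit of the assay. Compound 4 is therefore expected to give 95%, between 85% and 99%, most likely reported as another limit of the assay.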

Compound 4, percent of the compound remaining: > 95%
Compound 4 ended at the assay's limit; the forecaster's own chance of this, stated with the estimate: 85%; the middle value lies on the limit itself.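

No new step can be read from compound 1 to compound 4, since both compounds give a limit of the assay rather than a number in this assay: the limit of > 95% in this assay, at which 4 of the 4 values shown sit. The compounds shown leave open whether replacing 1-hydroxyethyl with 1-acetoxyethyl changes the percent of compound remaining at all, as none of them gives a value away from this limit.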